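Series notes: benzyl amide on the shared core

This account rests on a few compounds, and the source may have more. Where it says the series, first, only, none or still open, it means among the compounds named here.

Measured so far:
- compound 1 `C=CC1=C(C(=O)NCCC)C(c2ccc(F)cc2)OC1` in a functional assay on HeLa cells (Homo sapiens) for cytotoxicity, read by MTT assay, with a stated time of 24 h (on this read-out lower numbers stand for stronger inhibition and higher numbers for weaker inhibition), gives > 100000 nM; this value is a limit of the assay, not a number.
- compound 2 `C=CC1=C(C(=O)NCCCCC)C(c2ccc(Cl)c(Cl)c2)OC1` in this assay gives > 100000 nM; this value too is a limit of the assay.

Compound 1 therefore stands at the limit, and nothing else is known of it: the limit of > 100000 nM in this assay, at which 2 of the 2 values shown sit. Of the pair compound 1 and compound 2, both values sit at the same limit, so no order between them can be read.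

The next compound, compound 3 `C=CC1=C(C(=O)NCc2ccccc2)C(c2ccc(F)cc2)OC1`, differs from compound 1 in one place: phenyl in place of ethyl on a saturated chain carbon bound to an amide-type nitrogen. Going by the values given here, no measured step of this kind exists, so the size of the change in this assay cannot be read from the data. With compound 1 at its limit > 100000 nM, the step that the estimate below implies, a number no higher from compound 1 to compound 3 (the limit leaves the size open), is expected to be nothing beyond the usual scatter, if any. For compound 3 the estimated value is 100000 nM, expected to fall between 30000 nM and 300000 nM, with a good chance that only a limit is reported again.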

Compound 3, half-maximal inhibitory concentration: > 100000 nM
Compound 3: no number, only a limit; the forecaster's own chance of this, stated with the estimate: 70%; the middle value lies on the limit itself.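

In this assay compound 3 gives > 100000 nM, which is a limit of the assay. Going by these compounds alone, compound 1 also stands at a limit, so no step from compound 1 to compound 3 can be read. The compounds shown leave open how propyl to benzyl changes the value, and how any of these compounds would rank in this assay: the limit of > 100000 nM in this assay, at which 3 of the 3 values shown sit.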